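Ring substituent swaps on a shared phenylpropanoic acid scaffold

This account rests on a few compounds, and the source may have more. Where it says the series, first, only, none or still open, it means among the compounds named here.

Measured so far:
compound 1 `COc1ccc(F)c(N2CCC(COc3cccc(C(CC(=O)O)C4CC4)c3)CC2)c1` — 670 nM
compound 2 `COc1ccc(CCC(C)(C)O)c(N2CCC(COc3cccc(C(CC(=O)O)C4CC4)c3)CC2)c1` — 970 nM
compound 3 `COc1ccc(CN(C)CC(C)C)c(N2CCC(COc3cccc(C(CC(=O)O)C4CC4)c3)CC2)c1` — 1000 nM

All three compounds were tested in a functional assay on cells for agonist activity at Free fatty acid receptor 1 (Homo sapiens), read by FLIPR and calcium flux, with a stated time of 60 min; on this read-out higher numbers stand for an effect only at larger amounts of compound and lower numbers for an effect already at smaller amounts. Compound 1 gives the lowest of the three numbers, yet both of its neighbours sit within the scatter: a 1.4-fold higher number from compound 1 to compound 2 (0.16 log units; within the scatter) and a 1.5-fold higher number from compound 1 to compound 3 (0.17 log units; within the scatter). Compound 2 and compound 3 are likewise indistinguishable, a 1.0-fold higher number from compound 2 to compound 3 (0.01 log units; within the scatter). For the measured compounds named here, the series so far therefore shows no movement beyond the scatter when the fluoro of compound 1 is exchanged for either a 3-hydroxy-3-methylbutyl or an (isobutyl(methyl)amino)methyl group.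

Compound 4 `COc1ccc(C(=O)N(C)CC(C)(C)C)c(N2CCC(COc3cccc(C(CC(=O)O)C4CC4)c3)CC2)c1` is not yet measured. It differs from compound 1 at the same aromatic carbon: methyl(neopentyl)carbamoyl in place of fluoro on an aromatic carbon. The two steps that bear on this change, from compound 1 to compound 2 and from compound 1 to compound 3, each replaced the same fluoro with a larger group and each stayed within the scatter. On that basis no step beyond the scatter is expected in this assay for compound 4 either, with a slight lean toward a higher number because of a 1.4-fold higher number from compound 1 to compound 2 (0.16 log units; within the scatter) and a 1.5-fold higher number from compound 1 to compound 3 (0.17 log units; within the scatter) both pointing that way. The expected step is a 1.3-fold higher number from compound 1 to compound 4 (0.10 log units; within the scatter). Compound 4 is estimated at 850 nM, with a range from 400 nM to 1800 nM.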

Compound 4, half-maximal effective concentration: 100 nM
Beside the measured number, compound 4's estimate is 8.5-fold (0.93 log units) above it; measured number outside the range, below it.
By their numbers in this assay, from the lowest: compound 4; then compounds 1, 2 and 3 (each within the scatter of the next).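

In this assay, for the compounds shown here, the aromatic carbon para to a methoxy group proves sensitive to what it carries: methyl(neopentyl)carbamoyl in place of fluoro gives a 6.7-fold lower number from compound 1 to compound 4 (0.83 log units; beyond the scatter), the first step at this position beyond the scatter. The same group also separates from the other two large substituents, with a 9.7-fold lower number from compound 2 to compound 4 (0.99 log units; beyond the scatter) and a 10-fold lower number from compound 3 to compound 4 (1.00 log units; beyond the scatter), so a larger group at this carbon does not by itself set the number: 3-hydroxy-3-methylbutyl and (isobutyl(methyl)amino)methyl stay within the scatter of fluoro, whereas methyl(neopentyl)carbamoyl does not. Nothing at hand explains these steps.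

The compounds shown do not separate the carbonyl from the alkyl groups on the amide nitrogen, since the amine of compound 3 also carries a different alkyl group from the amide of compound 4; a ketone, or an amide with a neopentyl group and the amide hydrogen in place of the methyl, would address that. Also open, on these data alone, is how far the neopentyl group itself matters, which a dimethylcarbamoyl group or a pyrrolidine amide at the same carbon would test.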